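A benzyl group in place of an aryl group

The compounds below may be only part of what the source reports. "The series", "measured", "known", "first", "only" and "open" are said of these compounds alone.

Three compounds have been measured in an in vitro functional assay on HEK293-A cells for negative allosteric modulation of metabotropic glutamate receptor 5 (Homo sapiens), read by FLIPR and calcium flux; on this read-out lower numbers stand for stronger inhibition and higher numbers for weaker inhibition:

compound 1 `O=C1CC(c2nc(-c3cccc(Cl)c3)no2)CN1c1ccc(Cl)cc1`: > 10000 nM
compound 2 `O=C1CC(c2nc(-c3cccc(Cl)c3)no2)CN1c1ccc(Cl)c(Cl)c1`: > 10000 nM
compound 3 `C[C@H](c1ccccc1)N1C[C@H](c2nc(-c3cccc(Cl)c3)no2)CC1=O`: 1600 nM

Compound 2 returns a limit of the assay and not a number. Compound 1 also returns only a limit. Compound 2 therefore sits at the limit of > 10000 nM in this assay, at which 2 of the 3 values shown sit, together with compound 1, while compound 3 gives a number. Going by the values given here, the one measured step at the ring nitrogen, a step that the two limits leave unreadable from compound 1 to compound 2, cannot be read because both ends are limits.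

Compound 4 `O=C1CC(c2nc(-c3cccc(Cl)c3)no2)CN1Cc1ccc(F)cc1` differs from compound 2 by 4-fluorobenzyl in place of 3,4-dichlorophenyl on an amide-type nitrogen in a ring. Among the compounds with values here, no measured step covers this change, so the expectation rests on the fact that compound 3, which bears a different group on that same nitrogen, gives 1600 nM. Compound 1 and compound 2, which bear an aryl group there, each return only a limit. Compound 4 is therefore expected to move off the limit, with an estimated 3000 nM, within 800 nM to 10000 nM. The step of an at least 3.3-fold lower number from compound 2 to compound 4 (0.52 log units; beyond the scatter) is expected, but with low confidence.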

Compound 4, half-maximal inhibitory concentration: 3600 nM
Estimate against measurement, compound 4: 1.2-fold (0.08 log units) below; the range from low to high includes it.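

In this assay the change to 4-fluorobenzyl on the amide-type nitrogen in a ring gives an at least 2.7-fold lower number from compound 2 to compound 4 (0.44 log units; beyond the scatter) and also an at least 2.7-fold lower number from compound 1 to compound 4 (0.44 log units; beyond the scatter) with a readable number at the end of each step. This position therefore allows a measurable response with the shared core unchanged, even though the leaving and entering groups each hold 8 heavy atoms and one six-membered aromatic ring, and the earlier step at this nitrogen could not be read. Both new steps give only a minimum size, since compound 1 and compound 2 each stand at a limit of the assay: the limit of > 10000 nM in this assay, at which 2 of the 4 values shown sit.

From the compounds shown here alone, whether the change in compound 4 belongs to the added carbon link or to the fluorine stays open. Also open, going by these compounds, is how a plain benzyl, a 2-phenylethyl chain or a pyridylmethyl group would read on this nitrogen.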